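The compounds below may be only part of what the source reports. "The series", "measured", "known", "first", "only" and "open" are said of these compounds alone.

Among the compounds with values here, in a functional assay on CWR22R cells (Homo sapiens) for cytotoxicity, read by MTT assay, with a stated time of 72 h (on this read-out lower numbers stand for stronger inhibition and higher numbers for weaker inhibition), only two compounds have numbers so far. Compound 1 `CCOc1ccc(/C=C(\C(=O)/C=C/C2=C(C)CCCC2(C)C)C(=O)/C=C/c2ccc(OCC)c(OCC)c2)cc1OCC` gives 9300 nM. Compound 2 `COc1cc(/C=C/C(O)=C/C(=O)/C=C/C2=C(C)CCCC2(C)C)ccc1O` gives 10600 nM. These two values lie within the usual scatter of repeated measurements, so compound 2 stands level with compound 1 and neither can be ranked over the other.

Compound 3 `COc1cc(/C=C/C(O)=C/C(=O)/C=C/C2=C(C)CCCC2(C)C)cc(OC)c1O` keeps all of compound 2 apart from one edit: methoxy in place of hydrogen on an aromatic carbon. In words, this is methoxy in place of hydrogen on an aromatic carbon, and the new group is ortho to a hydroxy group.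

Within the data shown here, no two measured compounds differ in only one place, so the data give no direct measure of what such an edit does. Among the measured compounds shown here, the only guide is the narrow spread of the two known values, with compound 1 at 9300 nM and compound 2 at 10600 nM. A small change is therefore expected, perhaps none beyond the scatter, leaning if anything towards a lower number. The estimated step, a 1.4-fold lower number from compound 2 to compound 3 (0.15 log units; within the scatter), is modest and uncertain. For compound 3 the estimate is 7500 nM, with an expected range from 3000 nM to 16000 nM.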

Compound 3, half-maximal inhibitory concentration: 12200 nM
Beside the measured number, compound 3's estimate is 1.6-fold (0.21 log units) below it; the measured number falls inside the stated range.
By their numbers in this assay, from the lowest: compounds 1, 2 and 3 (each within the scatter of the next).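

Within the data shown here, compound 2 and compound 3 give the first comparison in which only one place differs, and in this assay the step for methoxy in place of hydrogen on an aromatic carbon is a 1.2-fold higher number from compound 2 to compound 3 (0.06 log units; within the scatter). At this carbon, ortho to a hydroxy group, the added methoxy therefore leaves compound 3 level with compound 2, so this pair shows no measurable effect of the edit on the read-out. Nothing measured here bears on why the two compounds stand level.

The compounds shown leave open whether the same position would stay level with a different kind of group there, such as an amine, a carboxylic acid or a longer chain like butoxy. They also leave open what replacing the hydroxy group itself would do, and whether any single edit to the shared core can give a step beyond the scatter in this assay.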